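This account rests on a few compounds, and the source may have more. Where it says the series, first, only, none or still open, it means among the compounds named here.

In a functional assay on A549 cells (Homo sapiens) for cytotoxicity, read by MTT assay, with a stated time of 72 h (a lower number here means a stronger inhibitor, a higher number a weaker inhibitor), compound 1 `CNC(=O)c1cc(Oc2ccc(C3=NNC(c4cccc([N+](=O)[O-])c4)C3)cc2)ccn1` has the entry "not determined" (no result reported) and so gives no result. Compound 2 `CNC(=O)c1cc(Oc2ccc(C3=NNC(c4ccc(OC)c(OC)c4OC)C3)cc2)ccn1` gives 19000 nM in the same test. Compound 3 `CNC(=O)c1cc(Oc2ccc(C3=NN(C(N)=S)C(c4cccc([N+](=O)[O-])c4)C3)cc2)ccn1` reads > 50000 nM there, and this is a limit of the assay and not a number. Compound 4 `CNC(=O)c1cc(Oc2ccc(C3=NN(C(N)=S)C(c4ccc(C#N)cc4)C3)cc2)ccn1` departs from compound 3 in one place, with 4-cyanophenyl in place of 3-nitrophenyl on a saturated ring carbon as the full change. Among the compounds with values here, no measured step shows what such a swap does in this assay here, so little change is expected, with an estimated at least 1.1-fold lower number from compound 3 to compound 4 (0.04 log units; that floor lies within the scatter) that stays within the scatter. For compound 4 the expected value is 45000 nM with an estimated range of 18000 nM to 100000 nM as its bounds.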

Compound 4, half-maximal inhibitory concentration: > 50000 nM
Compound 4 was reported as a limit (the forecaster's own chance of this, stated with the estimate: 55%); at least 1.1-fold (0.04 log units) between middle value and limit.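

No step can be read between compound 3 and compound 4, because each is reported only as a limit and not as a number: the limit of > 50000 nM in this assay, at which 2 of the 4 values shown sit.

The compounds shown leave open what 4-cyanophenyl in place of 3-nitrophenyl does in this assay.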